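A few compounds are considered here, and "the series" means these few. Any claim that something is new, unique, unknown or untested is made for them only; others in the source may bear on it.

Measured so far in a functional assay on P388 cells (Mus musculus) for inhibition, tested at 10 uM; on this read-out lower numbers stand for a weaker effect and higher numbers for a stronger effect at the one concentration tested:
compound 1 `COc1ccc2c(c1)c(-c1cc(C(F)(F)F)c(C#N)c(-c3cn(S(=O)(=O)c4ccc(C)cc4)c4ccc(OC)cc34)n1)cn2S(=O)(=O)c1ccc(C)cc1` gives 3.5%
compound 2 `COc1ccc2c(-c3cc(C(F)(F)F)c(C#N)c(-c4cn(S(=O)(=O)c5ccc(C)cc5)c5cc(OC)ccc45)n3)cn(S(=O)(=O)c3ccc(C)cc3)c2c1` gives 10.1%

Both readings are low, and compound 2 and compound 1 lie within the usual scatter of each other, so neither can be set apart from the other on these numbers. Compound 3 `COc1ccc2c(-c3cc(C(F)(F)F)cc(-c4cn(S(=O)(=O)c5ccc(C)cc5)c5cc(OC)ccc45)n3)cn(S(=O)(=O)c3ccc(C)cc3)c2c1` follows from compound 2 by one change: hydrogen in place of cyano on an aromatic carbon. Among the measured compounds shown here, no step between measured compounds is available to gauge this change, so the expectation rests on the two readings alone. Since compound 2 gives 10.1% and compound 1 gives 3.5%, no step beyond the scatter is expected in this assay. The expected step is a number 3.1 percentage points lower from compound 2 to compound 3 (within the scatter). Compound 3 is estimated at about 7%, with a range of 0% to 20%.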

Compound 3, a percentage reported as inhibition, at one concentration (the size of the read-out at that concentration, not a potency): 92.8%
Estimate against measurement, compound 3: 85.8 percentage points below, and the stated range ends below it.
By their numbers in this assay, from the lowest: compounds 1 and 2 (each within the scatter of the next); then compound 3.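

In this assay, the aromatic carbon ortho to a trifluoromethyl group and two atoms from the ring nitrogen proves decisive: hydrogen in place of cyano gives a number 82.7 percentage points higher from compound 2 to compound 3 (beyond the scatter). Compound 1 and compound 2 both carry the cyano and lie within the scatter of each other, so they gave no sign of how much this position matters. No evidence on the cause of this step is at hand.

On these data alone, whether the high reading needs hydrogen here, or would survive an amine, a methyl or a carboxylic acid on this carbon, stays open. A reading at one concentration also gives no potency for compound 3.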